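Swapping the fluorophenyl arm of compound 3 for methylphenyl

The source may report more compounds than this note shows. Statements on the series, on what has been measured and on what is new or still open speak of the compounds shown alone.

Going by the values given here, compound 3 `O=C(O)c1ccccc1-c1ccc(CCc2ncc(Cc3ccccc3F)[nH]2)cc1` stands lowest of the three numbers so far in an in vitro functional assay on cells for agonist activity at Bombesin receptor subtype-3 (Homo sapiens), read by luminescence and calcium flux (a higher number here means that more compound is needed for the effect, a lower number that less compound is needed), giving 177 nM. Compound 1 `CCCCc1cnc(C(C)Cc2ccc(-c3ccccc3C(=O)O)cc2)[nH]1` gives 2760 nM and compound 2 `CCCCc1cnc(C(CCCC)Cc2ccc(-c3ccccc3C(=O)O)cc2)[nH]1` gives 2660 nM; the step of a 1.0-fold lower number from compound 1 to compound 2 (0.02 log units; within the scatter) shows that propyl in place of hydrogen on a saturated chain carbon barely moves the number. Among the compounds with values here, compound 4 `Cc1ccc(Cc2cnc(CCc3ccc(-c4ccccc4C(=O)O)cc3)[nH]2)cc1` is the one not yet measured. 4-methylphenyl in place of 2-fluorophenyl on a saturated chain carbon bound to an aromatic carbon No measured step bears on an exchange of this kind; the single recorded step concerns a different chain carbon and lies within the scatter. The step of a 2.0-fold higher number from compound 3 to compound 4 (0.30 log units; within the scatter) is therefore expected to be small, with broad uncertainty around it. The estimate for compound 4 is 350 nM, within a range from 100 nM to 1200 nM.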

Compound 4, half-maximal effective concentration: 2660 nM
Compound 4: middle estimate off by 7.6-fold (0.88 log units), on the low side; the whole stated range lies below it.
By their numbers in this assay, from the lowest: compound 3; then compounds 2, 4 and 1 (each within the scatter of the next).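

In this assay, the exchange of 2-fluorophenyl for 4-methylphenyl gives a 15-fold higher number from compound 3 to compound 4 (1.18 log units; beyond the scatter), so this arm, on a saturated chain carbon bound to an aromatic carbon, strongly affects the number. Going by these compounds alone, the only earlier step, at a different chain carbon, stayed within the scatter. No available evidence accounts for the size of this step.

Fluorine gives way to methyl and the ring numbering changes from 2 to 4 in the same swap, so the two changes cannot be separated. As far as these compounds go, how a plain phenyl arm would compare also remains open.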